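A Methyl Enters the Five-Membered Ring of Compound 3

A few compounds are considered here, and "the series" means these few. Any claim that something is new, unique, unknown or untested is made for them only; others in the source may bear on it.

Compound 1, `O=C(O)CCNC(=O)c1ccc(C(Oc2ccc(-n3cc(C(F)(F)F)cn3)cc2)C2CCCC2)cc1`: 420 nM
Compound 2, `CCCC(Oc1ccc(-n2cc(C#N)cn2)cc1)c1ccc(C(=O)NCCC(=O)O)cc1`: 4100 nM
Compound 3, `CCCC(Oc1ccc(-n2cccn2)cc1)c1ccc(C(=O)NCCC(=O)O)cc1`: 4100 nM

All three compounds were measured in an assay on cells for displacement of a labelled ligand from Glucagon receptor (Homo sapiens), in the presence of a further agent that is not named here; on this read-out higher numbers stand for weaker inhibition and lower numbers for stronger inhibition. Compound 3 stands level with compound 2 and together they give the highest numbers of the three; compound 1 gives a lower number, but its structure differs from compound 3 in more than one place, so its value only marks where it stands. Among the compounds with values here, the one step that touches the same ring carbon is no change at the digits printed from compound 2 to compound 3 (within the scatter), hydrogen in place of cyano on an aromatic carbon, with no change beyond the scatter.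

The unmeasured compound 4 is `CCCC(Oc1ccc(-n2cc(C)cn2)cc1)c1ccc(C(=O)NCCC(=O)O)cc1`. methyl in place of hydrogen on an aromatic carbon

Within the data shown here, with the step of no change at the digits printed from compound 2 to compound 3 (within the scatter) as the only guide at this position, a methyl here is expected to leave the number essentially where it is, and the expected step is a 1.1-fold lower number from compound 3 to compound 4 (0.03 log units; within the scatter), no change beyond the scatter in either direction. Compound 4 is therefore estimated at 3800 nM, with a range from 1600 nM to 9000 nM.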

Compound 4, inhibition constant: 1900 nM
Compound 4: the middle estimate sits 2.0-fold (0.30 log units) above what was measured; the range from low to high includes it.
By their numbers in this assay, from the lowest: compound 1; then compound 4; then compounds 2 and 3 (each within the scatter of the next).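

In this assay, this ring carbon proves not to be indifferent to what it carries: methyl in place of hydrogen gives a 2.2-fold lower number from compound 3 to compound 4 (0.33 log units; beyond the scatter), and methyl in place of cyano gives a 2.2-fold lower number from compound 2 to compound 4 (0.33 log units; beyond the scatter). Both steps are modest, but the earlier step, no change at the digits printed from compound 2 to compound 3 (within the scatter), had shown no difference between hydrogen and cyano, so only methyl has moved the number beyond the scatter at this position. Nothing available here accounts for this result.

On these data alone, it remains open whether an ethyl group, a chlorine atom or a methoxy group on this ring carbon would lower the number further than methyl does. As far as these compounds go, compound 1, at 420 nM, carries trifluoromethyl here but differs elsewhere too, so what trifluoromethyl would do on the core of compound 4 also remains open.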